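Oxime ether variation on the shared core: growth inhibition

This account rests on a few compounds, and the source may have more. Where it says the series, first, only, none or still open, it means among the compounds named here.

Working notes on three measured compounds and one still pending. In a functional assay on MCF7 cells (Homo sapiens) for inhibition, read by sulforhodamine B assay, with a stated time of 48 h, tested at 50 uM (on this read-out lower numbers stand for less inhibition of growth and higher numbers for more inhibition of growth at the one concentration tested), compound 1 `COc1cc2c(cc1CC=C(C)C)/C(=N/NC(N)=O)C[C@@H](c1ccc(O)cc1)O2` gives 93%, compound 2 `COc1ccc([C@@H]2C/C(=N/OCc3cn(-c4ccccc4CO)nn3)c3cc(CC=C(C)C)c(OC)cc3O2)cc1` gives 100% and compound 3 `COc1cc2c(cc1CC=C(C)C)C(=O)C[C@@H](c1ccc(Oc3ccccc3)cc1)O2` gives 69%. Compound 2 holds the highest number of the three; its gap to compound 1 lies within the scatter, whereas its gap to compound 3 lies beyond it. Compound 4 `COc1ccc([C@@H]2C/C(=N/OCc3cn(-c4ccc(O)cc4)nn3)c3cc(CC=C(C)C)c(OC)cc3O2)cc1` carries the change (4-hydroxyphenyl in place of 2-(hydroxymethyl)phenyl on an aromatic nitrogen). Among the measured compounds shown here, no step between measured compounds isolates this change, so the expectation rests on compound 2 alone, whose value of 100% already sits at the top of the read-out in this assay. The expected step of a number 5 percentage points lower from compound 2 to compound 4 (within the scatter) is therefore small, downward if anything, and not beyond the scatter. For compound 4 the estimated value in this assay is 95%, with a range from 80% to 100%.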

Compound 4, percent growth inhibition at one concentration: 63%
Compound 4: the middle estimate sits 32 percentage points above what was measured; measured number below the stated range.
By their numbers in this assay, from the lowest: compounds 4 and 3 (each within the scatter of the next); then compounds 1 and 2 (each within the scatter of the next).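

In this assay the group on the aromatic nitrogen proves to matter, with a number 37 percentage points lower from compound 2 to compound 4 (beyond the scatter) for 4-hydroxyphenyl in place of 2-(hydroxymethyl)phenyl. The step arises although the hydrogen-bond donor and acceptor counts stay the same and neither group carries a net charge. Nothing available explains the step. Still open, going by these compounds, is whether the step follows from gaining 4-hydroxyphenyl or from losing 2-(hydroxymethyl)phenyl. An unsubstituted phenyl or a phenyl bearing an amine on the same nitrogen would help separate the two readings.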